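Methylation of a Phenol Carried to a Second Core

The source may hold more compounds than are shown below. What is called first, only, known or untested is meant among the compounds shown, and "the series" means these compounds.

Compound 1 `O=C(Nc1cccc(-n2cc(-c3ccncc3)c(-c3cc(O)cc(Cl)c3)n2)c1)Nc1ccc(Cl)c(Cl)c1`, compound 2 `COc1cc(Cl)cc(-c2nn(-c3cccc(NC(=O)Nc4ccc(Cl)c(Cl)c4)c3)cc2-c2ccncc2)c1` and compound 3 `O=C(Nc1cccc(-n2cc(-c3ccncc3)c(-c3cc(O)cc(Cl)c3)n2)c1)c1cc(C(F)(F)F)cc(C(F)(F)F)c1` were tested in a functional assay on HCC 2998 cells (Homo sapiens) for inhibition, read by sulforhodamine B assay, with a stated time of 48 h, tested at 10 uM; on this read-out lower numbers stand for a stronger effect and higher numbers for a weaker effect at the one concentration tested. In this assay compound 1 gives 0.57%, compound 2 gives 26.7% and compound 3 gives 28.9%. Compound 2 differs from compound 1 by methyl in place of hydrogen on an oxygen on an aromatic ring and this change made a step of a number 26.1 percentage points higher from compound 1 to compound 2 (beyond the scatter). The difference between the cores of compound 1 and compound 3 is not broken down here. Compound 4 `COc1cc(Cl)cc(-c2nn(-c3cccc(NC(=O)c4cc(C(F)(F)F)cc(C(F)(F)F)c4)c3)cc2-c2ccncc2)c1` has not yet been measured; it differs from compound 3 by methyl in place of hydrogen on an oxygen on an aromatic ring, the same change at the same place. Because a number 26.1 percentage points higher from compound 1 to compound 2 (beyond the scatter) moved the number upward, compound 4 is expected to shift by an estimated a number 23.1 percentage points higher from compound 3 to compound 4 (beyond the scatter) in this assay. In this assay compound 4 is therefore expected to come out near 52%, within an estimated span of 28% to 80%.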

Compound 4, a percentage reported as activity, at one concentration (the size of the read-out at that concentration, not a potency): 78.3%
Beside the measured number, compound 4's estimate is 26.3 percentage points below it, within the range that was stated.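

Putting methoxy in place of hydroxy on the core of compound 3 gave a number 49.4 percentage points higher from compound 3 to compound 4 (beyond the scatter) in this assay. The change weakened the effect on both cores, but its size did not carry over: the same change on two cores in this assay, a number 26.1 percentage points higher (beyond the scatter) from compound 1 to compound 2 and a number 49.4 percentage points higher (beyond the scatter) from compound 3 to compound 4, 23.3 percentage points apart, beyond the scatter of two such steps

These two pairs show the direction holding on the two cores shown, but they do not explain the gap in size or allow the size of the step on a further core to be read from them. The compounds shown leave open how a longer chain such as ethoxy, or an amine in place of the hydroxy, would behave on either core. They also leave open whether the gap between the two steps would persist on other cell lines.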